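Swapping methoxy for trifluoromethyl on a shared core

The source may hold more compounds than are shown below. What is called first, only, known or untested is meant among the compounds shown, and "the series" means these compounds.

- compound 1 `Clc1ccc2[nH]c(-c3cn(-c4ccccc4)nc3-c3ccccc3)nc2c1`: 3480 nM
- compound 2 `COc1ccc2[nH]c(-c3cn(-c4ccccc4)nc3-c3ccccc3)nc2c1`: 2870 nM

In a functional assay on HeLa cells (Homo sapiens) for antiproliferative activity, read by MTT assay, with a stated time of 48 h (on this read-out lower numbers stand for stronger inhibition and higher numbers for weaker inhibition), compound 2 gives 2870 nM, level with compound 1 within the scatter. Compound 3 `FC(F)(F)c1ccc2[nH]c(-c3cn(-c4ccccc4)nc3-c3ccccc3)nc2c1` differs from compound 2 by trifluoromethyl in place of methoxy on an aromatic carbon. Within the data shown here, one measured step bears on this place, a swap of methoxy in place of chloro: a 1.2-fold lower number from compound 1 to compound 2 (0.08 log units; within the scatter). That single step gives little to go on, so no change beyond the scatter is expected in this assay. The estimated step is a 1.0-fold higher number from compound 2 to compound 3 (0.02 log units; within the scatter). For compound 3 the expected value is 3000 nM, with an estimated range of 1300 nM to 7000 nM.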

Compound 3, half-maximal inhibitory concentration: 1920 nM
Compound 3: the middle estimate sits 1.6-fold (0.19 log units) above what was measured, and the stated range covers the measured number.
By their numbers in this assay, from the lowest: compounds 3, 2 and 1 (each within the scatter of the next).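

In this assay, trifluoromethyl on this aromatic carbon stays level with both earlier groups (a 1.5-fold lower number from compound 2 to compound 3 (0.17 log units; within the scatter); a 1.8-fold lower number from compound 1 to compound 3 (0.26 log units; within the scatter)). Chloro, methoxy and trifluoromethyl therefore all lie within the scatter of one another, so on these compounds this position shows no measurable response to the swap. Nothing available here offers an explanation for this. Going by these compounds, whether an amine, a carboxylic acid or a longer chain on this carbon would stay at the same level remains open.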